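Plasma stability notes: chain-linked benzoic acid series

A few compounds are considered here, and "the series" means these few. Any claim that something is new, unique, unknown or untested is made for them only; others in the source may bear on it.

Measured so far:
compound 1, `COc1cc(C(=O)O)ccc1OCCCCOc1ccc(C(=O)CC(C)(C)C)c(O)c1C`, 48%
compound 2, `Cc1c(OCCCCOc2ccc(C(=O)CC(C)(C)C)c(O)c2C)cccc1C(=O)O`, 89%
compound 3, `Cc1c(OCCCCOCOc2ccc(C(=O)O)cc2)ccc(C(=O)CC2CCCC2)c1O`, 100%

All three compounds were run in an ADME assay on a cell-free system (plasma, Rattus norvegicus) for metabolic stability, read by LC-MS, with a stated time of 60 min, tested at 100 uM; a higher number here means that more of the compound is left, a lower number that less of the compound is left. Compound 3 stands highest of the three numbers: compound 2 lies nearest, lower by a gap beyond the scatter, and compound 1 lies furthest off, also beyond the scatter. Among the compounds with values here, no pair among the measured compounds differs in one place only, so no single step can be read from them directly.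

The next compound, compound 4, `Cc1cc(C(=O)O)ccc1OCCCCOc1ccc(C(=O)CC2CCCC2)c(O)c1C`, is taken from compound 3 by one change: 4-carboxy-2-methylphenyl in place of (4-carboxyphenoxy)methyl on an oxygen on a saturated carbon. The chain now joins the carboxy-bearing ring directly through the ether oxygen, as it does in compound 2 and compound 1, and the methyl sits on the carboxy-bearing ring.

Compound 2 keeps a high fraction in this assay, and the methyl-bearing acid of compound 4 is closer to compound 2 than to compound 1, so a small downward step from compound 3 is expected, one that may fall within the scatter; the expected step is a number 12 percentage points lower from compound 3 to compound 4 (beyond the scatter). Compound 4 is therefore estimated at 88%, with a range from 72% to 100%.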

Compound 4, percent of the compound remaining: 99%
For compound 4 the middle estimate is 11 percentage points below the measured one; the range from low to high includes it.
By their numbers in this assay, from the lowest: compound 1; then compounds 2, 4 and 3 (each within the scatter of the next, the first and the last beyond it).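

In this assay, 4-carboxy-2-methylphenyl in place of (4-carboxyphenoxy)methyl on an oxygen on a saturated carbon gives a number 1 percentage points lower from compound 3 to compound 4 (within the scatter). Within the data shown here, this is the first single-place comparison, and it shows that this position accepts both groups with no change in the fraction left beyond the scatter, even though the entering group has one oxygen fewer and carries a ring methyl. No available evidence bears on why the two groups read alike here.

Among these compounds, the single step changes the link and the ring methyl together, so their separate contributions remain unresolved, and both compounds sit near the top of the scale, where a further gain would be hard to see. Also open, on these data alone, is how this position would respond to a tetrazole or a primary amide on that ring in place of the carboxylic acid.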